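Working notes on the step from compound 3 to compound 4

The compounds below may be only part of what the source reports. "The series", "measured", "known", "first", "only" and "open" are said of these compounds alone.

Of the compounds shown here, three on the shared core have been measured. Compound 1 `COc1ccc2[nH]c(C(=O)N3CC(=O)N(Cc4ccccc4)[C@@H](COc4ccccc4)C3)cc2c1` gives 0.65 h in an ADME assay on microsomes from liver (Homo sapiens) for metabolic stability, with a stated time of 30 min, tested at 1 uM; on this read-out higher numbers stand for a longer-lived compound and lower numbers for a shorter-lived compound. Compound 2 `COc1ccc2[nH]c(C(=O)N3CC(=O)N(Cc4ccccc4)[C@@H](CN4CCC5(CC4)CC5)C3)cc2c1` gives 0.867 h in this assay, and compound 3 `COc1ccc2[nH]c(C(=O)N3CC(=O)N(Cc4ccccc4)[C@@H](CN4CCC(C)CC4)C3)cc2c1` gives 0.267 h. Compound 3 holds the lowest of the three numbers: the step of a 2.4-fold lower number from compound 1 to compound 3 (0.39 log units; beyond the scatter) and the step of a 3.2-fold lower number from compound 2 to compound 3 (0.51 log units; beyond the scatter) both run downward and both lie beyond the scatter, whereas the step of a 1.3-fold higher number from compound 1 to compound 2 (0.13 log units; within the scatter) stays within it.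

Compound 4 `COc1ccc2[nH]c(C(=O)N3CC(=O)N(Cc4ccccc4)[C@@H](N4CCc5ccccc54)C3)cc2c1` is not yet measured. Relative to compound 3 the change is 2,3-dihydro-1H-indol-1-yl in place of (4-methylpiperidin-1-yl)methyl on a saturated ring carbon. Going by the values given here, no measured step involves the entering group. Among the compounds with values here, the steps that bear on it are the two leading into compound 3, a 2.4-fold lower number from compound 1 to compound 3 (0.39 log units; beyond the scatter) and a 3.2-fold lower number from compound 2 to compound 3 (0.51 log units; beyond the scatter), which show that the (4-methylpiperidin-1-yl)methyl group has so far gone with the lowest number of the set; compound 1, which like compound 4 carries one six-membered aromatic ring of carbon only, sits above compound 3. A modest step upward is therefore expected, a 1.9-fold higher number from compound 3 to compound 4 (0.27 log units; within the scatter). Compound 4 is estimated at 0.5 h in this assay, within 0.2 h to 1.2 h.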

Compound 4, half-life: 0.25 h
For compound 4 the middle estimate is 2.0-fold (0.30 log units) above the measured one, within the range that was stated.
By their numbers in this assay, from the lowest: compounds 4 and 3 (each within the scatter of the next); then compounds 1 and 2 (each within the scatter of the next).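

In this assay the change to 2,3-dihydro-1H-indol-1-yl in place of (4-methylpiperidin-1-yl)methyl on the saturated ring carbon gives a 1.1-fold lower number from compound 3 to compound 4 (0.03 log units; within the scatter) and so leaves the number where compound 3 already stood. The same group gives a 3.5-fold lower number from compound 2 to compound 4 (0.54 log units; beyond the scatter) and also a 2.6-fold lower number from compound 1 to compound 4 (0.41 log units; beyond the scatter) so a six-membered aromatic ring of carbon only in the group, present in both compound 1 and compound 4, does not by itself keep the number at the level of compound 1. The change swaps the ring system and removes the chain carbon at once, and these two parts cannot be separated here.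

As far as these compounds go, whether a morpholine or a carboxylic acid at this ring carbon would shift the number remains open, as does the effect of indoline on a methylene chain. Nothing measured here explains any of these steps.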